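Compound 4: tert-butyl in place of butyl

The source may hold more compounds than are shown below. What is called first, only, known or untested is meant among the compounds shown, and "the series" means these compounds.

In a functional assay on K562 cells (Homo sapiens) for cytotoxicity, read by MTT assay, with a stated time of 48 h (on this read-out higher numbers stand for weaker inhibition and lower numbers for stronger inhibition), three compounds on a shared core have been measured. Compound 1 (`CCN1C(=O)C(=O)c2cc(/C=C/C(=O)OC)ccc21`) gives 170 nM and compound 3 (`COC(=O)/C=C/c1ccc2c(c1)C(=O)C(=O)N2Cc1ccc(C#N)cc1`) gives 30 nM while compound 2 (`CCCCOC(=O)/C=C/c1ccc2c(c1)C(=O)C(=O)N2Cc1ccc(OC)cc1`) gives 40 nM on the same read-out. Compound 2 and compound 3 lie within the scatter of each other, and both stand clearly under compound 1, which has the highest number of the three.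

Compound 4 (`COc1ccc(CN2C(=O)C(=O)c3cc(/C=C/C(=O)OC(C)(C)C)ccc32)cc1`) is compound 2 with tert-butyl in place of butyl on an oxygen next to a carbonyl group. The two have the same atoms, joined differently.

Among the compounds with values here, the one measured step that changes a single place is a 5.7-fold lower number from compound 1 to compound 3 (0.75 log units; beyond the scatter) and it puts 4-cyanophenyl in place of methyl on a saturated chain carbon bound to an amide-type nitrogen in a ring. That is a different place, so this modest step gives no size for the present change. Within the data shown here, no measured step alters the group on the oxygen alone.

The expectation therefore stays anchored on compound 2 at 40 nM and no step beyond the scatter is expected in this assay for this change. The expected step is a 1.3-fold higher number from compound 2 to compound 4 (0.10 log units; within the scatter) and its direction is poorly fixed by the data. For compound 4 the estimated value is 50 nM with an expected range from 18 nM to 150 nM.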

Compound 4, half-maximal inhibitory concentration: 50 nM
Beside the measured number, compound 4's estimate shows no gap at the digits printed; low and high end bracket the measured number.
By their numbers in this assay, from the lowest: compounds 3, 2 and 4 (each within the scatter of the next); then compound 1.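

Within the data shown here, compound 4 supplies the first measured step that alters only the group on an oxygen next to a carbonyl group: in this assay, tert-butyl in place of butyl gives a 1.3-fold higher number from compound 2 to compound 4 (0.10 log units; within the scatter) and the rest of the structure stays the same. For this pair, rejoining the same atoms of this ester group therefore leaves the read-out within the scatter, so the butyl chain is not required in its unbranched form to keep compound 4 level with compound 2. This is a result for one pair on one background, and no measurement given here bears on the reason for it.

Going by these compounds, the reach of this tolerance remains open: a free carboxylic acid at this place, an amide carrying an amine-derived group, or a longer chain such as octyl on the oxygen could each behave differently. Among these compounds, the size of the group on this oxygen also remains unresolved, since no pair here isolates methyl against butyl or tert-butyl, and the compounds carrying methyl differ in the group on the ring nitrogen as well.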